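This account rests on a few compounds, and the source may have more. Where it says the series, first, only, none or still open, it means among the compounds named here.

Compound 2 `Cc1ccccc1OS(=O)(=O)c1ccc(NC(=O)NCCCCl)cc1` and compound 1 `O=C(NCCCCl)Nc1cccc(S(=O)(=O)Oc2ccc(O)cc2)c1` are two ureas that carry a sulfonate ester on a shared core. In a functional assay on HT-29 cells (Homo sapiens) for cytotoxicity, read by sulforhodamine B assay, with a stated time of 48 h (a higher number here means a weaker inhibitor, a lower number a stronger inhibitor), compound 2 gives 26000 nM, and compound 1 gives 51000 nM. Compound 2 thus has the lower of the two numbers, but its gap to compound 1 lies within the scatter, so the two cannot be ranked against each other.

Compound 3 `O=C(NCCCCl)Nc1ccc(S(=O)(=O)Oc2ccc(O)cc2)cc1` has not yet been measured. It differs from compound 2 in one respect: 4-hydroxyphenyl in place of 2-methylphenyl on an oxygen. Among the compounds with values here, no measured pair of compounds shows this change on its own, so its effect can only be estimated. Because compound 1 also carries the 4-hydroxyphenyl group and gives 51000 nM, a step from compound 2 to compound 3 that is small, toward a weaker inhibitor or none beyond the scatter, seems most likely; the expected step is a 1.3-fold higher number from compound 2 to compound 3 (0.13 log units; within the scatter). Compound 3 is therefore estimated at 35000 nM, within a range of 14000 nM to 90000 nM.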

Compound 3, half-maximal inhibitory concentration: 50000 nM
Estimate against measurement, compound 3: 1.4-fold (0.15 log units) below, and the stated range covers the measured number.
By their numbers in this assay, from the lowest: compounds 2, 3 and 1 (each within the scatter of the next).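

In this assay, within the data shown here, exchanging 2-methylphenyl for 4-hydroxyphenyl on the oxygen bonded to the sulfonyl sulfur gives a 1.9-fold higher number from compound 2 to compound 3 (0.28 log units; within the scatter) and offers the first direct reading of this change. A group with no hydrogen-bond donor is replaced by one with a hydrogen-bond donor, at the same count of heavy atoms, yet this pair shows no difference that can be told apart from the scatter. No supporting measurement is available to explain this result.

Only these two groups can be compared directly at this position, so a single pair cannot show how much the position tolerates in general. On these data alone, whether a phenyl ring carrying an amine or a carboxylic acid, or a longer chain on this oxygen, would move the number beyond the scatter remains open.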